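A Methyl Added to the Benzyl Group of Compound 1

The source may hold more compounds than are shown below. What is called first, only, known or untested is meant among the compounds shown, and "the series" means these compounds.

In a functional assay on A2780 cells (Homo sapiens) for antiproliferative activity, read by resazurin assay, with a stated time of 72 h (a lower number here means a stronger inhibitor, a higher number a weaker inhibitor), compound 1 `CN(Cc1cccc(F)c1)C(=O)c1cc2c(Cc3ccccc3)n[nH]c2cc1O` gives 5000 nM and compound 3 `CN(Cc1ccc(Br)cc1)C(=O)c1cc2c(Cc3ccccc3)n[nH]c2cc1O` gives 2800 nM as its result. Among the compounds with values here, these two cannot be told apart, since the step of a 1.8-fold lower number from compound 1 to compound 3 (0.25 log units; within the scatter) is the only measured comparison available. Compound 2 `Cc1cccc(CN(C)C(=O)c2cc3c(Cc4ccccc4)n[nH]c3cc2O)c1` also carries a methyl, on the group at the amide nitrogen, but its entry reads "not determined" (no result reported) and so offers no guide.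

Compound 4 `Cc1cccc(Cc2n[nH]c3cc(O)c(C(=O)N(C)Cc4cccc(F)c4)cc23)c1` keeps the amide side of compound 1 and turns the benzyl on the shared core into 3-methylbenzyl. Within the data shown here, the change is methyl in place of hydrogen on an aromatic carbon and no measured step touches that group. The nearest evidence is the step of a 1.8-fold lower number from compound 1 to compound 3 (0.25 log units; within the scatter) at the amide end, which stays within the scatter and gives no direction. A shift beyond the scatter is therefore not expected in this assay for this change. The expected result is a 1.3-fold lower number from compound 1 to compound 4 (0.10 log units; within the scatter) and this estimate carries no clear direction. Compound 4 is estimated at 4000 nM with an expected range from 1800 nM to 9000 nM in this assay when measured.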

Compound 4, half-maximal inhibitory concentration: 440 nM
Compound 4: middle estimate off by 9.1-fold (0.96 log units), on the high side; measured number below the stated range.
By their numbers in this assay, from the lowest: compound 4; then compounds 3 and 1 (each within the scatter of the next).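

In this assay, the benzyl group on the shared core proves to be a place where a very small addition matters: one methyl in place of a hydrogen on an aromatic carbon gives an 11-fold lower number from compound 1 to compound 4 (1.06 log units; beyond the scatter). The only earlier step, at the amide end, was a 1.8-fold lower number from compound 1 to compound 3 (0.25 log units; within the scatter), so this is the first change among these compounds to lie beyond the scatter. Within the data shown here, nothing measured here explains why this one methyl moves the number so far.

The compounds shown leave open whether an ethyl, a methoxy or a chlorine at the same carbon would match compound 4 or give a different result. They also leave open whether the same methyl would give a similar step when the amide carries the 4-bromophenyl group of compound 3.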